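A thiazolyl amide in place of the pyridyl amide

A few compounds are considered here, and "the series" means these few. Any claim that something is new, unique, unknown or untested is made for them only; others in the source may bear on it.

Three amides built on one shared core have been examined in a physicochemical assay for solubility, in phosphate buffer, measured as kinetic solubility, with a stated time of 1 h, at pH 7.4; on this read-out higher numbers stand for higher solubility and lower numbers for lower solubility. Compound 1 `COc1ccc2nc(C)cc(OCC(=O)Nc3cccc(C)c3)c2c1` gives 193000 nM, compound 2 `COc1ccc2nc(C)cc(OCC(=O)Nc3cc(C)c(F)c(C)c3)c2c1` gives 31500 nM, and compound 3 `COc1ccc2nc(C)cc(OCC(=O)Nc3c(C)cncc3C)c2c1` gives 12000 nM. Compound 3 thus stands lowest of the three in this assay: its nearest neighbour is compound 2, and the change was a 2.6-fold lower number from compound 2 to compound 3 (0.42 log units; beyond the scatter), while against compound 1 the change was a 16-fold lower number from compound 1 to compound 3 (1.21 log units; beyond the scatter). The remaining step, a 6.1-fold lower number from compound 1 to compound 2 (0.79 log units; beyond the scatter), shows that exchanging the ring on the amide nitrogen has moved the read-out each time it was tried.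

Compound 4 `COc1ccc2nc(C)cc(OCC(=O)Nc3nc(C)c(C)s3)c2c1` continues this series with 4,5-dimethyl-1,3-thiazol-2-yl in place of 3,5-dimethylpyridin-4-yl on an amide-type nitrogen. Going by the values given here, none of the measured steps involves a five-membered ring with two hetero atoms, so no step speaks directly to this exchange; the measured steps only show that changes at this position have been modest to large in this assay. Compound 4 is therefore expected to land near compound 3, with a step of a 2.0-fold lower number from compound 3 to compound 4 (0.30 log units; within the scatter), and its estimated solubility is 6000 nM, with a range from 1500 nM to 20000 nM.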

Compound 4, solubility: 31500 nM
Beside the measured number, compound 4's estimate is 5.3-fold (0.72 log units) below it; measured number above the stated range.
By their numbers in this assay, from the lowest: compound 3; then compounds 2 and 4 (each within the scatter of the next); then compound 1.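

In this assay, 4,5-dimethyl-1,3-thiazol-2-yl on the amide-type nitrogen, the first five-membered ring with 2 hetero atoms at this position, gives a 2.6-fold higher number from compound 3 to compound 4 (0.42 log units; beyond the scatter) and leaves compound 3 as the lowest of the four. Against the 4-fluoro-3,5-dimethylphenyl amide the exchange shows no change at the digits printed from compound 2 to compound 4 (within the scatter) in this read-out, and against the 3-methylphenyl amide it shows a 6.1-fold lower number from compound 1 to compound 4 (0.79 log units; beyond the scatter) in the same read-out, so this position has now taken a five-membered and a six-membered ring with no measurable gap between them, while compound 1 still stands apart from both. Nothing available here accounts for these numbers.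

The compounds shown leave open what the methyl groups on the thiazolyl ring contribute, a question that an unsubstituted 1,3-thiazol-2-yl amide would address directly. They also leave open whether a morpholine, an amine or a carboxylic acid carried on this ring would bring the number in this assay back towards that of compound 1, or whether the read-out would stay with those of compound 2 and compound 4.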